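This account rests on a few compounds, and the source may have more. Where it says the series, first, only, none or still open, it means among the compounds named here.

Going by the values given here, in an ADME assay on NHDF cells (Homo sapiens) for cytotoxicity, read by MTT assay, with a stated time of 72 h (on this read-out higher numbers stand for weaker inhibition and lower numbers for stronger inhibition), two compounds sharing one core have numbers so far. Compound 1 (`COc1cccc(/C=C2\CCC/C(=C\c3cccc(OC)c3OC)C2=O)c1`) gives 16400 nM, and compound 2 (`COc1ccc(/C=C2\CCC/C(=C\c3cccc(Cl)c3)C2=O)cc1OC`) gives 11900 nM, a value within the usual scatter of the other, so neither stands apart. Compound 3 (`COc1ccccc1/C=C1\CCC/C(=C\c2ccc(OC)c(OC)c2)C1=O`) has yet to be measured in this assay. It differs from compound 2 in one place, on a double-bonded chain carbon bound to a double-bonded ring carbon, where 2-methoxyphenyl stands in place of 3-chlorophenyl: 2-methoxyphenyl in place of 3-chlorophenyl on a double-bonded chain carbon bound to a double-bonded ring carbon. Among the compounds with values here, no measured pair isolates this change. Compound 1, which carries no chlorine, sits at 16400 nM, within the scatter of compound 2 at 11900 nM, so no step beyond the scatter is expected in this assay. The estimated 1.2-fold higher number from compound 2 to compound 3 (0.07 log units; within the scatter) is therefore small. For compound 3 the expected value is 14000 nM, with an estimated range of 6500 nM to 30000 nM.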

Compound 3, half-maximal inhibitory concentration: 18100 nM
Beside the measured number, compound 3's estimate is 1.3-fold (0.11 log units) below it; the measured number falls inside the stated range.
By their numbers in this assay, from the lowest: compounds 2, 1 and 3 (each within the scatter of the next).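

In this assay, the exchange of 3-chlorophenyl for 2-methoxyphenyl on a double-bonded chain carbon bound to a double-bonded ring carbon can now be read directly as a 1.5-fold higher number from compound 2 to compound 3 (0.18 log units; within the scatter) and stays within the scatter. The earlier compounds shown here offered no pair that isolated this place, whereas this pair shows that a chlorine-bearing phenyl and a methoxy-bearing phenyl, the latter with one hydrogen-bond acceptor that the former lacks, cannot be told apart here. Nothing available explains why these two groups read alike.

The compounds shown leave open whether any group at this place can give a number beyond the scatter, since only substituted phenyl groups appear there. An amine or a carboxylic acid on that phenyl ring, or a pyridine in place of it, could test this.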